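Swapping an aromatic ring for a silicon-bearing group

A few compounds are considered here, and "the series" means these few. Any claim that something is new, unique, unknown or untested is made for them only; others in the source may bear on it.

Three measured compounds share one core and differ only in the group sitting on an aromatic carbon of a five-membered aromatic ring with 3 nitrogen. In a functional assay on A549 cells (Homo sapiens) for antiproliferative activity, read by MTT assay, with a stated time of 72 h (on this read-out lower numbers stand for stronger inhibition and higher numbers for weaker inhibition), compound 1 `O=C1O[C@H]([C@@H](O)Cn2cc(-c3ccc(Br)cc3)nn2)C(OCc2ccccc2)=C1OCc1ccccc1` gives 750 nM. Compound 2 `O=C1O[C@H]([C@@H](O)Cn2cc(-c3cccc(O)c3)nn2)C(OCc2ccccc2)=C1OCc1ccccc1` gives 59900 nM in this assay, the highest of the two numbers shown, so it is the weaker of the pair. The step of an 80-fold higher number from compound 1 to compound 2 (1.90 log units; beyond the scatter) shows that this one group can move the result a long way. Compound 3 `CC(C)(C)OC(=O)N1CCN(C(=S)SCc2cn(C[C@H](O)[C@H]3OC(=O)C(OCc4ccccc4)=C3OCc3ccccc3)nn2)CC1`, which carries a much larger group, reaches only a limit in this assay, > 100000 nM. That limit is the limit of > 100000 nM in this assay, at which 1 of the 3 values shown sits.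

Compound 4 `C[Si](C)(C)c1cn(C[C@H](O)[C@H]2OC(=O)C(OCc3ccccc3)=C2OCc2ccccc2)nn1` is not yet measured. Compared with compound 2, the change is a group of 4 heavy atoms (3 carbon, 1 silicon; no ring) in place of a group of 7 heavy atoms (6 carbon, 1 oxygen; one six-membered aromatic ring of carbon only), on an aromatic carbon. Among the compounds with values here, no measured step shares this change; the only measured step, from compound 1 to compound 2, put 3-hydroxyphenyl in place of 4-bromophenyl and was large, so the group at this place clearly matters, but it gives no direction for a group of 3 carbon and 1 silicon with no ring. A step of moderate size is therefore expected, with real uncertainty about its direction and a fair chance that compound 4 only reaches the limit. Compound 4 is estimated at 15000 nM, within 2000 nM to 100000 nM, which means an expected step of a 4.0-fold lower number from compound 2 to compound 4 (0.60 log units; beyond the scatter).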

Compound 4, half-maximal inhibitory concentration: 19200 nM
Estimate against measurement, compound 4: 1.3-fold (0.11 log units) below; the range from low to high includes it.
By their numbers in this assay, from the lowest: compound 1; then compound 4; then compound 2. At a limit, above all of these: compound 3.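

In this assay the silicon-bearing group, which has no ring, does better than 3-hydroxyphenyl on this aromatic carbon, with a 3.1-fold lower number from compound 2 to compound 4 (0.49 log units; beyond the scatter), so a six-membered aromatic ring at this place is not needed to reach a lower number than compound 2 gives. The same group falls well short of 4-bromophenyl, with a 26-fold higher number from compound 1 to compound 4 (1.41 log units; beyond the scatter), so the two ring-bearing groups land on either side of it, and the presence of a ring does not by itself set the order among these three compounds. The order is clear, but nothing measured among these compounds explains why it runs this way.

Going by these compounds, it remains open whether the silicon atom itself matters, a question that a tert-butyl group, the all-carbon counterpart of the new group, placed on the same aromatic carbon could help to answer. On these data alone, it also remains open how much of the lead of compound 1 belongs to the bromine and how much to the ring, which a plain phenyl group at this place could begin to separate.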